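Methyl on selenium: a step without precedent in the set

The compounds below may be only part of what the source reports. "The series", "measured", "known", "first", "only" and "open" are said of these compounds alone.

Compound 1 `COc1ccc(CNc2nc([SeH])nc3ccccc23)cc1` gives 71300 nM in an ADME assay on 184B5 cells (Homo sapiens) for cytotoxicity, read by MTT assay, with a stated time of 72 h; on this read-out lower numbers stand for stronger inhibition of growth and higher numbers for weaker inhibition of growth; compound 2 `[SeH]c1nc(NCc2ccccc2)c2ccccc2n1` gives 20800 nM in this assay. Among the compounds with values here, the only measured step is a 3.4-fold lower number from compound 1 to compound 2 (0.54 log units; beyond the scatter). Compound 2 therefore stands at the lowest of the two numbers, with compound 1 the nearest. Compound 3 `C[Se]c1nc(NCc2ccccc2)c2ccccc2n1` differs from compound 2 by methyl in place of hydrogen on a selenium. Within the data shown here, the one measured step concerns an aromatic carbon and says nothing about the selenium, so no measured step bears on this change. For compound 3 the expected step in this assay is a 1.0-fold lower number from compound 2 to compound 3 (0.02 log units; within the scatter), none beyond the scatter. Compound 3 is estimated at 20000 nM, within 7000 nM to 60000 nM.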

Compound 3, concentration for 50% growth inhibition: 3720 nM
Beside the measured number, compound 3's estimate is 5.4-fold (0.73 log units) above it; the whole stated range lies above it.
By their numbers in this assay, from the lowest: compound 3; then compound 2; then compound 1.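

Selenium is a position that responds in this assay: methyl in place of hydrogen gives a 5.6-fold lower number from compound 2 to compound 3 (0.75 log units; beyond the scatter). The hydrogen on selenium is therefore not needed for growth inhibition in this pair, and a substituent there can lower the number beyond the scatter. No supporting measurement accounts for this step.

Going by these compounds, whether an ethyl group or a longer chain on selenium would continue this step remains open, as does the effect of a terminal amine or carboxylic acid on such a chain. Also open, on these data alone, is whether methoxy on the aromatic carbon would have the same effect with methyl on selenium.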